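Methoxy added on the fused ring: series notes

The compounds below may be only part of what the source reports. "The series", "measured", "known", "first", "only" and "open" are said of these compounds alone.

Measured so far in a functional assay on A2780 cells (Homo sapiens) for antiproliferative activity, read by MTT assay, with a stated time of 48 h; a higher number here means a weaker inhibitor, a lower number a stronger inhibitor:
compound 1 `COc1ccc2c(/C=C/C(=O)c3cc(OC)c(OC)c(SC)c3)c[nH]c2c1` — 139 nM
compound 2 `COc1cc(C(=O)/C=C/c2c[nH]c3ccccc23)cc(SC)c1OC` — 169 nM
compound 3 `COc1cc(C(=O)/C=C/c2cn(C)c3ccccc23)cc([N+](=O)[O-])c1OC` — 1890 nM

Going by the values given here, compound 1 and compound 2 sit close together; the only change between them is methoxy in place of hydrogen on an aromatic carbon and the step it made, a 1.2-fold lower number from compound 2 to compound 1 (0.08 log units; within the scatter), is within the scatter, so no order between the two is claimed. Compound 3 gives the highest number of the three; it stands well apart from both, and the difference between its core and the core of compound 2 is not broken down here.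

Compound 4 `COc1ccc2c(/C=C/C(=O)c3cc(OC)c(OC)c([N+](=O)[O-])c3)cn(C)c2c1` has not been measured. It differs from compound 3 by methoxy in place of hydrogen on an aromatic carbon. Among the compounds with values here, this is the same change as the one from compound 2 to compound 1, at a place described in the same words, so the earlier step is the only guide available. For compound 4 the expected step is a 1.2-fold lower number from compound 3 to compound 4 (0.07 log units; within the scatter), close to a 1.2-fold lower number from compound 2 to compound 1 (0.08 log units; within the scatter) and therefore within the scatter, because that single precedent a 1.2-fold lower number from compound 2 to compound 1 (0.08 log units; within the scatter) moved the number only slightly. Compound 4 is accordingly estimated at 1600 nM in this assay, with a likely range of 700 nM to 3600 nM; this rests on one pair of compounds only and a second pair could fall elsewhere.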

Compound 4, half-maximal inhibitory concentration: 952 nM
For compound 4 the middle estimate is 1.7-fold (0.23 log units) above the measured one; the measured number falls inside the stated range.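

In this assay the new step is a 2.0-fold lower number from compound 3 to compound 4 (0.30 log units; within the scatter), so methoxy in place of hydrogen on an aromatic carbon of the fused ring again leaves the number within the scatter, now on a second core. Set side by side, the two steps do not differ by more than repeat measurements would allow: the same change on two cores in this assay, a 1.2-fold lower number (0.08 log units; within the scatter) from compound 2 to compound 1 and a 2.0-fold lower number (0.30 log units; within the scatter) from compound 3 to compound 4, 1.6-fold (0.21 log units) apart, within the scatter of two such steps

Carrying this change from one core to the other therefore gave a consistent result in these two pairs, with neither step large enough to show that the methoxy changes the number at all, and two pairs establish no rule for any other core in the series.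

The compounds shown leave open whether a different group at this place, such as an amine, a carboxylic acid or a longer chain like ethoxy, would move the number beyond the scatter, and whether methoxy on another carbon of the same ring would behave as it does here. Going by these compounds alone, no pair among them changes the nitro group or the methylthio group alone, so what either contributes to the number remains unresolved.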